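Replacing the dimethylamino end with an ethyl ester chain

The source may report more compounds than this note shows. Statements on the series, on what has been measured and on what is new or still open speak of the compounds shown alone.

In a functional assay for inhibition (on this read-out lower numbers stand for stronger inhibition and higher numbers for weaker inhibition), compound 3 `CN(C)CCCOc1ccc2c(=O)cc(-c3cc(C(C)(C)C)c(O)c(C(C)(C)C)c3)oc2c1` gives 700 nM, the lower of the two single numbers in the series. Compound 1 `CC(C)(C)c1cc(-c2cc(=O)c3ccc(OCCO)cc3o2)cc(C(C)(C)C)c1O` gives 3000 nM, while compound 2 `CC(C)(C)c1cc(-c2cc(=O)c3ccc(OCC(=O)O)cc3o2)cc(C(C)(C)C)c1O` gives 3000 nM; 100 nM (2 entries), with no single number. Compound 4 `CCOC(=O)CCCCOc1ccc2c(=O)cc(-c3cc(C(C)(C)C)c(O)c(C(C)(C)C)c3)oc2c1` differs from compound 3 by (ethoxycarbonyl)methyl in place of dimethylamino on a saturated chain carbon, three bonds along the chain from an oxygen on an aromatic ring. Among the measured compounds shown here, the one measured step bearing on this is modest: a 4.3-fold lower number from compound 1 to compound 3 (0.63 log units; beyond the scatter). With the dimethylamino group gone, a partial return towards compound 1 at 3000 nM is expected, giving a 2.1-fold higher number from compound 3 to compound 4 (0.33 log units; beyond the scatter). The range stays wide because the several entries of compound 2 in this assay, 3000 nM; 100 nM (2 entries) lie far apart. Compound 4 is estimated at 1500 nM, within 350 nM to 6000 nM.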

Compound 4, half-maximal inhibitory concentration: 3000 nM
Beside the measured number, compound 4's estimate is 2.0-fold (0.30 log units) below it, and the stated range covers the measured number.
By their numbers in this assay, from the lowest: compound 3; then compounds 1 and 4 (each within the scatter of the next).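

In this assay, an ester end does not keep the lower number seen with the dimethylamino end (a 4.3-fold higher number from compound 3 to compound 4 (0.63 log units; beyond the scatter)). The 4-(ethoxycarbonyl)butyl chain cannot be told apart from the hydroxy-ended chain (no change at the digits printed from compound 1 to compound 4 (within the scatter)), so among these three compounds only the 3-(dimethylamino)propyl chain stands apart. Nothing shown accounts for this difference.

Open, on these data alone, is whether the lower number follows the amine itself, as a pyrrolidine or morpholine end on the same chain would test. A 4-carboxybutyl chain would separate the ester from its free carboxylic acid.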